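Changing the Aryl Group on a Shared Core

This account rests on a few compounds, and the source may have more. Where it says the series, first, only, none or still open, it means among the compounds named here.

Measured compounds:
compound 1, `Cc1nn(-c2nc(-c3ccc(Cl)c(Cl)c3)c(SC(C)C)s2)c(C(=O)O)c1-c1cncnc1`: 22000 nM
compound 2, `Cc1nn(-c2nc(-c3ccc(Cl)c(Cl)c3)c(SC(C)C)s2)c(C(=O)O)c1-c1cccc(F)c1`: 900 nM
compound 3, `Cc1nn(-c2nc(-c3ccc(Cl)c(Cl)c3)c(SC(C)C)s2)c(C(=O)O)c1-c1ccc(Cl)cc1`: 2500 nM

In a functional assay on BJAB cells (Homo sapiens) for antiproliferative activity, with a stated time of 4 days (on this read-out higher numbers stand for an effect only at larger amounts of compound and lower numbers for an effect already at smaller amounts), compound 3 stands second highest of the three: an 8.8-fold lower number from compound 1 to compound 3 (0.94 log units; beyond the scatter), while a 2.8-fold higher number from compound 2 to compound 3 (0.44 log units; beyond the scatter). Compound 4 `Cc1nn(-c2nc(-c3ccc(Cl)c(Cl)c3)c(SC(C)C)s2)c(C(=O)O)c1-c1ccccc1[N+](=O)[O-]` differs from compound 3 by 2-nitrophenyl in place of 4-chlorophenyl on an aromatic carbon. All three measured steps change this same aromatic group, so all bear on the change: a 24-fold lower number from compound 1 to compound 2 (1.39 log units; beyond the scatter) and an 8.8-fold lower number from compound 1 to compound 3 (0.94 log units; beyond the scatter) were large to modest, and a 2.8-fold higher number from compound 2 to compound 3 (0.44 log units; beyond the scatter) modest. Halogenated phenyl rings gave the lower numbers; a nitrogen-containing ring gave the highest. For compound 4 a modest rise is expected, a 2.0-fold higher number from compound 3 to compound 4 (0.30 log units; within the scatter), so compound 4 is estimated at 5000 nM, within 1200 nM to 20000 nM.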

Compound 4, half-maximal effective concentration: 4700 nM
The estimate for compound 4 lay 1.1-fold (0.03 log units) above the measured number; the measured number falls inside the stated range.
By their numbers in this assay, from the lowest: compound 2; then compounds 3 and 4 (each within the scatter of the next); then compound 1.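

At this position on the shared core, 2-nitrophenyl cannot be told apart from 4-chlorophenyl in this assay, with a 1.9-fold higher number from compound 3 to compound 4 (0.27 log units; within the scatter). The step to 3-fluorophenyl is clearer, with a 5.2-fold higher number from compound 2 to compound 4 (0.72 log units; beyond the scatter), and a phenyl ring without a halogen also gives a lower number than pyrimidin-5-yl, with a 4.7-fold lower number from compound 1 to compound 4 (0.67 log units; beyond the scatter). No measurement here explains these differences.

As far as these compounds go, whether the kind of group on the phenyl ring or where it sits matters more stays open, as the three phenyl rings differ in both. From the compounds shown here alone, how a phenyl ring carrying an amine or a methoxy group would behave also remains open.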